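The source may hold more compounds than are shown below. What is called first, only, known or untested is meant among the compounds shown, and "the series" means these compounds.

In a functional assay on A-375 cells (Homo sapiens) for antiproliferative activity, read by MTT assay, with a stated time of 24 h (on this read-out higher numbers stand for weaker inhibition and lower numbers for stronger inhibition), compound 1 `CCc1ccc2nc(C(=O)Nc3c(F)cc(-c4cccc(F)c4)cc3F)c(C)c(C(=O)O)c2c1` gives 57800 nM and compound 2 `CCOc1ccc2nc(C(=O)Nc3c(F)cc(-c4cccc(F)c4)cc3F)c(C)c(C(=O)O)c2c1` gives 14900 nM, the lower of the two numbers. Among the measured compounds shown here, the one measured step, a 3.9-fold lower number from compound 1 to compound 2 (0.59 log units; beyond the scatter), is modest but beyond the scatter, and it puts ethoxy in place of ethyl on an aromatic carbon. Compound 3 `COc1ccc2nc(C(=O)Nc3c(F)cc(-c4cccc(F)c4)cc3F)c(C)c(C(=O)O)c2c1` has not yet been measured. It differs from compound 2 by hydrogen in place of methyl on a saturated chain carbon bound to an oxygen on an aromatic ring, turning ethoxy into methoxy. For the measured compounds named here, no measured pair shortens such a chain, so that single step bears on this change only indirectly. A smaller step than a 3.9-fold lower number from compound 1 to compound 2 (0.59 log units; beyond the scatter) is expected, towards a slightly higher number and probably within the scatter. The expected step is a 1.3-fold higher number from compound 2 to compound 3 (0.11 log units; within the scatter). In this assay, the estimate for compound 3 is 19000 nM, with an expected range from 8000 nM to 45000 nM.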

Compound 3, half-maximal inhibitory concentration: > 100000 nM
Compound 3: no number, only a limit; the forecaster's own chance of this, stated with the estimate: 5%; at least 5.2-fold (0.72 log units) between middle value and limit.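

In this assay compound 3 gives > 100000 nM, which is a limit of the assay and not a number: the limit of > 100000 nM in this assay, at which 1 of the 3 values shown sits. Removing a single methyl from the ethoxy group is therefore no minor trim at this place, as the result is an at least 6.7-fold higher number from compound 2 to compound 3 (0.82 log units; beyond the scatter). The oxygen on the aromatic carbon does not carry the earlier gain by itself: methoxy in place of ethyl gives an at least 1.7-fold higher number from compound 1 to compound 3 (0.23 log units; that floor lies within the scatter), whereas ethoxy in place of ethyl gave a 3.9-fold lower number from compound 1 to compound 2 (0.59 log units; beyond the scatter), so among these three compounds only the ethoxy group goes with the lower number.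

On these data alone, the true number of compound 3 stays unknown, so how far methoxy falls behind ethoxy remains open. As far as these compounds go, whether a longer chain such as propoxy, or an amine at this place, would lower the number further also remains open.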